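The compounds below may be only part of what the source reports. "The series", "measured", "known", "first", "only" and "open" are said of these compounds alone.

Measured in an ADME assay on microsomes (Rattus norvegicus) for metabolic stability; on this read-out lower numbers stand for a shorter-lived compound and higher numbers for a longer-lived compound:
- compound 1 `CC(C)(C)C(=O)N1CCSC1c1ccccc1`: 0.0533 h
- compound 2 `CC(C)(C)C(=O)N1N=CCC1c1cocn1`: > 1.5 h (a limit, not a number)

Compound 2 has no exact half-life and sits at the limit of > 1.5 h in this assay, at which 1 of the 2 values shown sits. Its true value is therefore open on the long-lived side.

Compound 3 `CC(C)(C)C(=O)N1N=CCC1C1CCCC1` keeps the core of compound 2 and carries cyclopentyl in place of 1,3-oxazol-4-yl on a saturated ring carbon.

Among the measured compounds shown here, no two measured compounds differ in one place only, so this change has no direct precedent in this assay. The only hint is indirect and weak. Compound 1 also lacks the 1,3-oxazol-4-yl group, has a different core, and gives 0.0533 h. On that basis, a shift beyond the scatter towards a shorter-lived compound is expected, though not one that reaches as far down as that value. The expected size is an at least 3.7-fold lower number from compound 2 to compound 3 (0.57 log units; beyond the scatter), and it remains uncertain because the starting point is only a limit. For compound 3 the estimate is 0.4 h, with an expected range from 0.1 h to 1.5 h.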

Compound 3, half-life: 0.0433 h
For compound 3 the middle estimate is 9.2-fold (0.97 log units) above the measured one; the whole stated range lies above it.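

In this assay, the group on the saturated ring carbon proves decisive for the read-out: with the core of compound 2 held constant, cyclopentyl in place of 1,3-oxazol-4-yl gives an at least 34-fold lower number from compound 2 to compound 3 (1.53 log units; beyond the scatter). Both groups are five-membered rings with the same number of heavy atoms, so neither ring size nor heavy-atom count separates this pair, while aromatic character and the ring hetero atoms do differ. The size of the step is only a minimum, because compound 2 carries a limit and not a number: the limit of > 1.5 h in this assay, at which 1 of the 3 values shown sits.

This single pair does not show whether the aromatic ring, the ring nitrogen or the ring oxygen of 1,3-oxazol-4-yl accounts for the difference, and a furan-2-yl, a 1,3-thiazol-4-yl or a pyrrolidin-3-yl group at this carbon would help separate those features. Also open, as far as these compounds go, is whether a step of this size holds on another core, or with an open-chain group such as isopropyl or a longer alkyl chain in place of the ring.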